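Indole acrylonitrile series: removing the aryl methoxy

The compounds below may be only part of what the source reports. "The series", "measured", "known", "first", "only" and "open" are said of these compounds alone.

Measured so far:
- compound 1 `COc1ccc(-c2[nH]c3ccccc3c2/C=C(\C#N)S(=O)(=O)c2ccccc2)cc1`: 203 nM
- compound 2 `CCOC(=O)C(=Cc1c(-c2ccccc2)[nH]c2ccccc12)C(=O)OCC`: 3400 nM
- compound 3 `COc1ccc(-c2[nH]c3ccc(OC)cc3c2C=C(C#N)C#N)cc1`: 122 nM

All three numbers come from a functional assay on MDA-MB-435 cells (Homo sapiens) for inhibition, read by sulforhodamine B assay, with a stated time of 48 h; a lower number here means a stronger inhibitor of growth, a higher number a weaker inhibitor of growth. Compound 1 sits second highest of the three. Its nearest neighbour is compound 3, whose number is lower but within the scatter, so no order between compound 1 and compound 3 can be claimed. The furthest is compound 2, which lies well beyond the scatter and stands out as a weaker inhibitor of growth than compound 1 in this assay. No pair among these three differs in only one place, so no single measured step is available to calibrate the change considered here.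

The next compound is compound 4 `N#C/C(=C\c1c(-c2ccccc2)[nH]c2ccccc12)S(=O)(=O)c1ccccc1`. It differs from compound 1 as follows: hydrogen in place of methoxy on an aromatic carbon. Within the data shown here, compound 2, the only compound without the methoxy, carries a different substitution on the exocyclic double bond as well, so it does not isolate this change. The expectation is a modest loss in this assay: the step from compound 1 to compound 4 is estimated at a 2.5-fold higher number from compound 1 to compound 4 (0.39 log units; beyond the scatter), somewhat beyond the scatter but uncertain in size. On that basis compound 4 is expected to give about 500 nM in this assay, with a range from 150 nM to 1700 nM.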

Compound 4, concentration for 50% growth inhibition: 288 nM
The estimate for compound 4 lay 1.7-fold (0.24 log units) above the measured number; measured number inside the range.
By their numbers in this assay, from the lowest: compounds 3, 1 and 4 (each within the scatter of the next, the first and the last beyond it); then compound 2.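

Among these compounds, the change from 4-methoxyphenyl to phenyl, hydrogen in place of methoxy on an aromatic carbon para to a large group, can now be read directly in this assay as a 1.4-fold higher number from compound 1 to compound 4 (0.15 log units; within the scatter), the first step between compounds that differ in one place. The step lies within the scatter, so no order can be claimed between the pair, and with the rest of the structure held as in compound 1, this position can carry hydrogen or methoxy without a measurable difference in growth inhibition. No measurement shown here offers an explanation for this result.

The compounds shown leave open whether this position accepts groups other than hydrogen and methoxy, such as a hydroxyl, a dimethylamino group, a carboxylic acid or a longer chain like butoxy. Also open, from the compounds shown here alone, is whether the same result holds with the two nitriles of compound 3 or the two ethyl esters of compound 2 on the exocyclic double bond, as neither compound has a partner here that differs only in this methoxy.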